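The source may report more compounds than this note shows. Statements on the series, on what has been measured and on what is new or still open speak of the compounds shown alone.

Measured compounds:
compound 1 `C=C(Br)C(=O)Nc1cccc(-c2cn3nc(-c4ccc(CC)cc4)sc3n2)c1`: 3400 nM
compound 2 `C=C(Br)C(=O)Nc1cccc(-c2cn3nc(Cc4cccc(OC)c4)sc3n2)c1`: 3100 nM
compound 3 `C=C(Br)C(=O)Nc1cccc(-c2cn3nc(-c4ccccc4)sc3n2)c1`: 960 nM

These three share one core and were tested in a functional assay on CCRF-CEM cells (Homo sapiens) for inhibition, read by cell counting, with a stated time of 3 days; a lower number here means a stronger inhibitor, a higher number a weaker inhibitor. Compound 1 shows the highest number of the three, though the step of a 1.1-fold lower number from compound 1 to compound 2 (0.04 log units; within the scatter) is too small to set the two apart. The step of a 3.5-fold lower number from compound 1 to compound 3 (0.55 log units; beyond the scatter) is modest but beyond the scatter, as is a 3.2-fold lower number from compound 2 to compound 3 (0.51 log units; beyond the scatter), so compound 3 gives the lowest number of the set.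

Compound 4 `C=C(Br)C(=O)Nc1cccc(-c2cn3nc(-c4ccc(OCC)cc4)sc3n2)c1` has not yet been measured. Its difference from compound 1 is ethoxy in place of ethyl on an aromatic carbon. For the measured compounds named here, no measured step exchanges one group at this position for another of similar size; the only related step is a 3.5-fold lower number from compound 1 to compound 3 (0.55 log units; beyond the scatter), in which the group was removed entirely. Compound 4 keeps a group of comparable size in the same place, so the change from compound 1 is expected to stay within the scatter, with at most a slight drift toward a lower number. The expected step is a 1.2-fold lower number from compound 1 to compound 4 (0.08 log units; within the scatter). In this assay compound 4 is therefore estimated at 2800 nM, with a range from 1200 nM to 6500 nM.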

Compound 4, half-maximal inhibitory concentration: 1400 nM
Estimate against measurement, compound 4: 2.0-fold (0.30 log units) above, and the stated range covers the measured number.
By their numbers in this assay, from the lowest: compounds 3 and 4 (each within the scatter of the next); then compounds 2 and 1 (each within the scatter of the next).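

In this assay, there is a 2.4-fold lower number from compound 1 to compound 4 (0.39 log units; beyond the scatter), so at this position, para to a large group, the oxygen that turns ethyl into ethoxy is enough to change the result beyond the scatter. Compounds 1 and 3 alone could suggest that any group here raises the number, but compound 4 goes against that, with a 1.5-fold higher number from compound 3 to compound 4 (0.16 log units; within the scatter) leaving ethoxy and hydrogen not separable. The 4-ethoxyphenyl compound also stands apart from the 3-methoxybenzyl compound, with a 2.2-fold lower number from compound 2 to compound 4 (0.35 log units; beyond the scatter), whereas the 4-ethylphenyl compound does not.

No measured evidence gives a reason for these steps. Going by these compounds, it remains open whether methoxy, a longer chain such as butoxy, an amine or a carboxylic acid at this position would stay close to compound 4 or move toward compound 1.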